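Acyl change at the ring nitrogen: compound 3 to compound 4

The source may hold more compounds than are shown below. What is called first, only, known or untested is meant among the compounds shown, and "the series" means these compounds.

All numbers come from a functional assay on NCI-H1975 cells (Homo sapiens) for inhibition, read by sulforhodamine B assay, tested at 10 uM; a higher number here means more inhibition at the concentration tested (going by the name of the read-out), a lower number less inhibition.
Compound 1 `CN1CCN(c2ccc(C3=NNC(c4ccc(N(C)C)cc4)C3)cc2)CC1`: 2.4%
Compound 2 `CC(=O)N1N=C(c2ccc(N3CCN(C)CC3)cc2)CC1c1ccc(N(C)C)cc1`: -1.9%
Compound 3 `CC(=O)N1N=C(c2ccc(-n3cncn3)cc2)CC1c1ccc(N(C)C)cc1`: -0.3%

Compound 3 is second highest of the three, with compound 2 nearest and compound 1 furthest; both gaps lie within the scatter, and none of the three shows inhibition beyond it in this assay.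

Compound 4 `CN(C)c1ccc(C2CC(c3ccc(-n4cncn4)cc3)=NN2C(=O)c2ccc(F)cc2)cc1` differs from compound 3 by 4-fluorophenyl in place of methyl on a carbonyl carbon. Going by the values given here, the only measured step at the same place, the ring nitrogen, is a number 4.3 percentage points lower from compound 1 to compound 2 (within the scatter), within the scatter. The other step, a number 1.6 percentage points higher from compound 2 to compound 3 (within the scatter), is also within the scatter. Among the compounds with values here, with no step in the set reaching beyond the scatter, a step of a number 3.3 percentage points higher from compound 3 to compound 4 (within the scatter) is expected, none beyond the scatter.

Compound 4 is therefore estimated at 3%, with a range from -10% to 18%.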

Compound 4, a percentage reported as inhibition, at one concentration (the size of the read-out at that concentration, not a potency): -1.1%
For compound 4 the middle estimate is 4.1 percentage points above the measured one; low and high end bracket the measured number.
By their numbers in this assay, from the lowest: compounds 2, 4, 3 and 1 (each within the scatter of the next).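

In this assay, going by these compounds alone, the first change at this carbonyl carbon replaces methyl with an aromatic ring, acetyl to (4-fluorophenyl)carbonyl, and gives a number 0.8 percentage points lower from compound 3 to compound 4 (within the scatter). Even this larger group, with 7 heavy atoms in place of 1, leaves the read-out within the scatter, so the two acyl groups cannot be told apart here. Nothing available bears on why the read-out stays flat at this position. Open, from the compounds shown here alone, is whether a longer chain, an amine or a carboxylic acid on this carbonyl carbon would give inhibition beyond the scatter.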